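Trimming a Carbonyl Side Chain Down to a Carboxylic Acid

The source may report more compounds than this note shows. Statements on the series, on what has been measured and on what is new or still open speak of the compounds shown alone.

Compound 3 `CCCSc1nc(Cl)c2c(n1)N(Cc1ccccc1)C(C(=O)NCCNC(=O)OC(C)(C)C)N2` gives 29700 nM in a functional assay on PC-3 cells (Homo sapiens) for antiproliferative activity, read by MTT assay, with a stated time of 72 h (a lower number here means a stronger inhibitor, a higher number a weaker inhibitor), the highest of the numbers measured here. Compound 2 `CCCSc1nc(Cl)c2c(n1)N(Cc1cccs1)C(C(=O)N1CCN(C)CC1)N2` gives 5020 nM in this assay, a lower number. Compound 1 `CCCSc1nc(Cl)c2c(n1)N(CCNC(=O)OC(C)(C)C)C(C(=O)N1CCN(C)CC1)N2` gives > 64000 nM in this assay, which is the limit of > 64000 nM in this assay, at which 1 of the 3 values shown sits. Within the data shown here, the only step measured, an at least 12-fold lower number from compound 1 to compound 2 (1.10 log units; beyond the scatter), alters the group on the ring nitrogen and leaves the carbonyl side untouched. Compound 4 `CCCSc1nc(Cl)c2c(n1)N(Cc1ccccc1)C(C(=O)O)N2` differs from compound 3 at that carbonyl: hydroxy in place of (2-((tert-butoxycarbonyl)amino)ethyl)amino on a carbonyl carbon. Among the measured compounds shown here, no measured step covers this position, so the change is uncharted. The expectation is a step of a 1.7-fold higher number from compound 3 to compound 4 (0.23 log units; within the scatter), toward a weaker compound, with a real chance that only a limit is reported. Compound 4 is therefore estimated at 50000 nM, within 15000 nM to 200000 nM.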

Compound 4, half-maximal inhibitory concentration: 49200 nM
Compound 4: middle estimate off by 1.0-fold (0.01 log units), on the high side; the measured number falls inside the stated range.
By their numbers in this assay, from the lowest: compound 2; then compounds 3 and 4 (each within the scatter of the next). At a limit, above all of these: compound 1.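

At this carbonyl carbon, replacing the whole chain with hydroxy gives a 1.7-fold higher number from compound 3 to compound 4 (0.22 log units; within the scatter) in this assay. With the rest of the molecule unchanged, losing this chain and its tert-butoxycarbonyl group therefore makes no change beyond the scatter. Compound 1 alone remains at a limit of the assay: the limit of > 64000 nM in this assay, at which 1 of the 4 values shown sits.

Open, going by these compounds, is whether a free amine at the end of the (2-aminoethyl)amino chain, or a longer chain, would shift the number beyond the scatter. On these data alone, a simple primary amide at this carbonyl carbon is equally open.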